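Bromo at the methoxymethyl position of the biaryl triazole series

The source may hold more compounds than are shown below. What is called first, only, known or untested is meant among the compounds shown, and "the series" means these compounds.

Measured so far in an assay on C6 glioma cells for displacement of a labelled ligand from sodium- and chloride-dependent glycine transporter 1 (Rattus norvegicus), read by scintillation counting, with stated times of 30 min and 10 min; on this read-out higher numbers stand for weaker inhibition and lower numbers for stronger inhibition:
compound 1 `CCc1nnc(-c2ccc(-c3ccccc3)cc2)n1-c1cccc(CO)c1C` gives 250 nM
compound 2 `CCc1nnc(-c2ccc(-c3ccccc3)cc2)n1-c1cccc(COC)c1C` gives 2400 nM

Within the data shown here, compound 2 carries the higher of the two numbers in this assay; its only neighbour is compound 1, and the step of a 9.6-fold higher number from compound 1 to compound 2 (0.98 log units; beyond the scatter) separates them. Among the measured compounds shown here, that step changes the same position that is altered next, so it is the one measurement bearing on the new compound, and it shows this position to be sensitive, beyond the scatter.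

Compound 3 `CCc1nnc(-c2ccc(-c3ccccc3)cc2)n1-c1cccc(Br)c1C` differs from compound 2 by bromo in place of methoxymethyl on an aromatic carbon. For the measured compounds named here, no measured step covers bromo, so the direction cannot be read from the data; the single relevant step only says a change here can move the number markedly. The expectation is therefore a move back toward the lower number of compound 1, of uncertain size, as a 4.8-fold lower number from compound 2 to compound 3 (0.68 log units; beyond the scatter). For compound 3 the estimate in this assay is 500 nM, within 100 nM to 2500 nM.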

Compound 3, half-maximal inhibitory concentration: 2200 nM
The estimate for compound 3 lay 4.4-fold (0.64 log units) below the measured number; measured number inside the range.
By their numbers in this assay, from the lowest: compound 1; then compounds 3 and 2 (each within the scatter of the next).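

In this assay, bromo in place of methoxymethyl gives a 1.1-fold lower number from compound 2 to compound 3 (0.04 log units; within the scatter), so the two groups do not separate at this position, although bromo is the smaller by heavy-atom count and has no oxygen. Against hydroxymethyl, the same bromo gives an 8.8-fold higher number from compound 1 to compound 3 (0.94 log units; beyond the scatter), which leaves compound 1 alone at the low end of the three compounds and shows that removing the ether oxygen and the carbon chain does not restore its number. No supporting measurement accounts for this separation of hydroxymethyl from the other two groups.

Still open, as far as these compounds go, is whether an amine, a carboxylic acid or a primary amide at this position would approach compound 1 and its 250 nM. Equally open, from the compounds shown here alone, is how a longer hydroxyalkyl chain or a nitrile would read here.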